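The compounds below may be only part of what the source reports. "The series", "measured", "known", "first", "only" and "open" are said of these compounds alone.

Measured compounds in a functional assay on L1210 cells (Mus musculus) for inhibition, read by cell counting, with a stated time of 2 days; on this read-out lower numbers stand for stronger inhibition and higher numbers for weaker inhibition:
- compound 1 `C=C(Br)C(=O)Nc1cccc(-c2cn3nc(Cc4cccc(OC)c4)sc3n2)c1`: compound 1 gives 2000 nM
- compound 2 `Nc1cccc(-c2cn3nc(-c4ccc(F)cc4)sc3n2)c1`: compound 2 gives only a limit, >= 250000 nM
- compound 3 `COc1cccc(Cc2nn3cc(-c4cccc(N)c4)nc3s2)c1`: compound 3 gives 21000 nM

Compound 1 stands lowest of the two numbers in this assay; its nearest neighbour is compound 3, and the value of compound 2 is a limit of the assay rather than a number (the limit of >= 250000 nM in this assay, at which 1 of the 3 values shown sits).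

For the measured compounds named here, the only measured step is an 11-fold higher number from compound 1 to compound 3 (1.02 log units; beyond the scatter), which removes the (1-bromoethenyl)carbonyl from the nitrogen on the aromatic ring and leaves the rest of the core untouched. Compound 4 `C=C(Br)C(=O)Nc1cccc(-c2cn3nc(-c4ccccc4)sc3n2)c1` keeps that group and instead alters the other end of the core: phenyl in place of 3-methoxybenzyl on an aromatic carbon. Going by the values given here, no measured step bears on this change directly. Compound 2 and compound 3 both lack the (1-bromoethenyl)carbonyl and carry different aryl groups on the same carbon, but they differ in more than one place, so their two values show only that a directly attached aryl sits at the limit where a 3-methoxybenzyl gives a number.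

On that basis a somewhat weaker result is expected for compound 4, with the step of a 4.0-fold higher number from compound 1 to compound 4 (0.60 log units; beyond the scatter) estimated and wide uncertainty. Compound 4 is estimated at 8000 nM, in the range 2000 nM to 40000 nM.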

Compound 4, half-maximal inhibitory concentration: 600 nM
For compound 4 the middle estimate is 13-fold (1.12 log units) above the measured one; the measured number lies below the stated range.
By their numbers in this assay, from the lowest: compound 4; then compound 1; then compound 3. At a limit, above all of these: compound 2.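

In this assay, the aromatic carbon next to the ring nitrogen and next to the ring sulfur now has a measured change of its own, and replacing 3-methoxybenzyl with phenyl gives a 3.3-fold lower number from compound 1 to compound 4 (0.52 log units; beyond the scatter), a step beyond the scatter. With the (1-bromoethenyl)carbonyl kept on the nitrogen, the 3-methoxybenzyl is therefore not required at this carbon for a number in this range, since phenyl, with fewer heavy atoms and without the oxygen, goes with the lower number. This rests on a single pair, and nothing shown gives a cause for the step.

Open, from the compounds shown here alone, is whether the lower number extends to other groups on this carbon, such as a 2-phenylethyl chain, a pyridyl ring or a plain methyl, and whether the same change reads alike with the free amine in place of the (1-bromoethenyl)carbonyl. Compound 2 gives only a limit, which leaves the second question without a number: the limit of >= 250000 nM in this assay, at which 1 of the 4 values shown sits.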